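The source may hold more compounds than are shown below. What is called first, only, known or untested is meant among the compounds shown, and "the series" means these compounds.

In a functional assay on the whole organism (strain Kunming) for inhibition, with Mus musculus as the target, in the writhing test, at a dose of 40 mg/kg by the oral route (on this read-out lower numbers stand for less inhibition and higher numbers for more inhibition at the one dose given (going by the name of the read-out)), the three measured compounds stand as follows:

compound 1 `CNC(=O)c1cc(-c2ccc(F)cc2F)ccc1OC(C)=O`: 29.9%
compound 2 `CC(=O)Oc1ccc(-c2ccc(F)cc2F)cc1C(=O)Nc1ccccc1C`: 12.3%
compound 3 `CNC(=O)c1cc(-c2ccc(F)cc2F)ccc1OC(=O)c1ccccc1`: 47.5%

Compound 3 holds the highest of the three numbers: the gap a number 17.6 percentage points higher from compound 1 to compound 3 (beyond the scatter) came with phenyl in place of methyl on a carbonyl carbon, and compound 2 lies further below still. Compound 4 `CN1CCN(NC(=O)c2cc(-c3ccc(F)cc3F)ccc2OC(=O)c2ccccc2)CC1` differs from compound 3 in one place: 4-methylpiperazin-1-yl in place of methyl on an amide-type nitrogen. Among the measured compounds shown here, the only measured step at that same place is a number 17.6 percentage points lower from compound 1 to compound 2 (beyond the scatter), with 2-methylphenyl in place of methyl on an amide-type nitrogen. The step of a number 17.6 percentage points higher from compound 1 to compound 3 (beyond the scatter) concerns another place and says nothing about the direction here. The step therefore expected is a modest fall, a number 12.5 percentage points lower from compound 3 to compound 4 (beyond the scatter), with the caution that 4-methylpiperazin-1-yl is unlike 2-methylphenyl and the evidence rests on one step. The estimate for compound 4 in this assay is 35%, within 15% to 55%.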

Compound 4, a percentage reported as inhibition, in the whole organism at one dose (the size of the read-out at that dose, not a potency): 88.3%
The estimate for compound 4 lay 53.3 percentage points below the measured number, outside the stated range (above it).
By their numbers in this assay, from the lowest: compound 2; then compound 1; then compound 3; then compound 4.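

In this assay, the amide-type nitrogen proved able to move the number upward as well as downward: 4-methylpiperazin-1-yl in place of methyl gave a large rise, a number 40.8 percentage points higher from compound 3 to compound 4 (beyond the scatter), whereas 2-methylphenyl had given a fall, a number 17.6 percentage points lower from compound 1 to compound 2 (beyond the scatter). The direction at this place therefore depends on the group that enters, although the two steps stand on different carbonyl substituents. No evidence at hand accounts for the rise. On these data alone, it remains open whether piperidin-1-yl or morpholin-4-yl would do the same at this nitrogen. Also open, as far as these compounds go, is whether 4-methylpiperazin-1-yl would raise the number with methyl on the carbonyl carbon, as in compound 1.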